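Hydroxy in place of hydrogen on the pendant ring

The source may hold more compounds than are shown below. What is called first, only, known or untested is meant among the compounds shown, and "the series" means these compounds.

Compound 1 `O=C1/C(=C/c2ccccc2)Cc2cc(O)ccc21` was tested in an assay on isolated protein for inhibition of Amine oxidase [flavin-containing] A (Homo sapiens), read by fluorescence and spectrophotometry, with a stated time of 20 min (on this read-out lower numbers stand for stronger inhibition and higher numbers for weaker inhibition), and gave 1940 nM. That number is the higher of the two measured, and the nearest measured compound is compound 2 `O=C1/C(=C/c2ccc(F)cc2)Cc2cc(O)ccc21`, which gave 679 nM in this assay. For the measured compounds named here, the only measured step between them, a 2.9-fold lower number from compound 1 to compound 2 (0.46 log units; beyond the scatter), is fluoro in place of hydrogen on an aromatic carbon of the pendant ring.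

Compound 3 `O=C1/C(=C/c2cccc(O)c2)Cc2cc(O)ccc21` has not yet been measured. It differs from compound 1 by hydroxy in place of hydrogen on an aromatic carbon, the hydroxy sitting on an aromatic carbon of a six-membered aromatic ring of carbon only. Going by the values given here, no measured step involves a hydroxy on that ring, so the only bearing evidence is the fluoro step from compound 1 to compound 2, which was modest and went toward a lower number. On that basis a change of similar size in the same direction in this assay is expected for compound 3, though with wide uncertainty. The estimate for compound 3 is 1000 nM, from 300 nM to 3500 nM, a step of a 1.9-fold lower number from compound 1 to compound 3 (0.29 log units; within the scatter) from compound 1.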

Compound 3, half-maximal inhibitory concentration: 1200 nM
Compound 3: the middle estimate sits 1.2-fold (0.08 log units) below what was measured; the range from low to high includes it.
By their numbers in this assay, from the lowest: compounds 2, 3 and 1 (each within the scatter of the next, the first and the last beyond it).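

With a hydroxy on an aromatic carbon of the pendant ring, meta to a large group, this assay shows a 1.6-fold lower number from compound 1 to compound 3 (0.21 log units; within the scatter), so on this read-out the change cannot be told apart from leaving the hydrogen in place. The earlier step, a 2.9-fold lower number from compound 1 to compound 2 (0.46 log units; beyond the scatter), lay beyond the scatter, so these two steps together show that putting a group on this ring does not always shift the number by more than the scatter. No measurement shown here accounts for the difference between the hydroxy and fluoro results.

The compounds shown leave open what a fluoro would do in the place now held by the hydroxy, so the effect of the group cannot be separated from the effect of its place on the ring. They also leave open whether an amine, a methoxy group or a carboxylic acid meta to a large group would move the number in this assay beyond the scatter, and in which direction.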